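This account rests on a few compounds, and the source may have more. Where it says the series, first, only, none or still open, it means among the compounds named here.

Three closely related compounds have been tested in a functional assay on HT-29 cells (Homo sapiens) for antiproliferative activity, read by MTT assay, with a stated time of 72 h; on this read-out higher numbers stand for weaker inhibition and lower numbers for stronger inhibition. Compound 1 `COc1cc2c(Oc3ccc(Nc4nccc5[nH]cc(-c6ccc(F)cc6)c(=O)c45)cc3F)ccnc2cc1OCCO` gives 2900 nM, compound 2 `COCCOc1cc2nccc(Oc3ccc(Nc4nccc5[nH]cc(-c6ccc(F)cc6)c(=O)c45)cc3F)c2cc1OC` gives 4600 nM, and compound 3 `CC(C)(O)COc1ccc2c(Oc3ccc(Nc4nccc5[nH]cc(-c6ccccc6)c(=O)c45)cc3F)ccnc2c1` gives 4200 nM. These numbers all lie within the usual scatter of one another, so compound 2 cannot be clearly separated from either of the other two.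

The open case is compound 4 `COCCOc1ccc2c(Oc3ccc(Nc4nccc5[nH]cc(-c6ccc(F)cc6)c(=O)c45)cc3F)ccnc2c1`, which differs from compound 2 in one place: hydrogen in place of methoxy on an aromatic carbon. The 2-methoxyethoxy group stays. Only one measured step links two of these compounds, a 1.6-fold higher number from compound 1 to compound 2 (0.20 log units; within the scatter), and it lies within the scatter. That step swaps methyl for hydrogen on an oxygen, not the methoxy that leaves here, so it bears on this change only indirectly. Compound 3 is a nearer guide, since it also lacks a methoxy on that ring, although it differs elsewhere too. Compound 3 gives 4200 nM, a value within the scatter of compound 2. Going by the values given here, no measured pair isolates this change, so no shift beyond the scatter is expected in this assay, in either direction.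

The expected step is a 1.2-fold lower number from compound 2 to compound 4 (0.06 log units; within the scatter). For compound 4 the estimated value is 4000 nM, with an expected range of 1800 nM to 9000 nM.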

Compound 4, half-maximal inhibitory concentration: 6500 nM
Estimate against measurement, compound 4: 1.6-fold (0.21 log units) below; low and high end bracket the measured number.
By their numbers in this assay, from the lowest: compounds 1, 3, 2 and 4 (each within the scatter of the next, the first and the last beyond it).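

In this assay, going by these compounds alone, the first direct reading of this change is a 1.4-fold higher number from compound 2 to compound 4 (0.15 log units; within the scatter). Within the data shown here, the methoxy on this aromatic carbon, ortho to a 2-methoxyethoxy group, can therefore give way to hydrogen in this pair with no separable effect on the read-out, whereas the only earlier step, at the chain's end oxygen, did not touch this carbon. No measurement shown offers an explanation for this result.

The compounds shown carry only methoxy or hydrogen at this carbon, so it remains open whether a different group there, such as an amine, a chlorine atom or a longer alkoxy chain, would move the number beyond the scatter. From the compounds shown here alone, it is also open whether removing the methoxy would read the same with another chain in place of the 2-methoxyethoxy group, such as the hydroxyethoxy chain of compound 1, since this single pair tests the change with just one neighbouring group.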